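Following the step from compound 3 to compound 4

The compounds below may be only part of what the source reports. "The series", "measured", "known", "first", "only" and "open" are said of these compounds alone.

Compound 1 (`COc1cccc2cc(-c3ccccc3)c(O)nc12`): 10000 nM
Compound 2 (`COc1ccc(-c2cc3c(OC)ccc(OC)c3nc2O)cc1`): 10000 nM
Compound 3 (`COc1ccc(-c2cc3c(OC)cc(OC)cc3n(CC(=O)OCc3ccccc3)c2=O)cc1`): 10000 nM

All three compounds were tested in a functional assay on A549 cells (Homo sapiens) for cytotoxicity, read by colorimetric assay and MTT assay; a higher number here means a weaker inhibitor, a lower number a stronger inhibitor. Compound 1 and compound 2 stand level with compound 3 at 10000 nM, so nothing separates the three beyond the scatter. Compound 4 (`COc1ccc(-c2cc3c(OC)cc(OC)cc3n(CCC(=O)OCc3ccccc3)c2=O)cc1`) has not yet been measured. It differs from compound 3 in a single place: (benzyloxycarbonyl)methyl in place of benzyloxycarbonyl on a saturated chain carbon bound to an aromatic nitrogen. Put in words, (benzyloxycarbonyl)methyl stands in place of benzyloxycarbonyl on a saturated chain carbon bound to an aromatic nitrogen. Among the compounds with values here, no measured pair here differs in only one place, so the data offer no direct precedent for this change. The expectation therefore rests on compound 3 alone, whose reading is 10000 nM, and no step beyond the scatter is expected in either direction. The expected size of no change at the digits printed from compound 3 to compound 4 (within the scatter) is correspondingly small. For compound 4 the estimated value is 10000 nM, with an expected range of 4000 nM to 15000 nM.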

Compound 4, half-maximal inhibitory concentration: 10000 nM
Compound 4: the middle estimate sits on the measured number at the digits printed; the measured number falls inside the stated range.
By their numbers in this assay, from the lowest: compounds 1, 2, 3 and 4 (each within the scatter of the next).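

In this assay, within the data shown here, the change of benzyloxycarbonyl to (benzyloxycarbonyl)methyl on a saturated chain carbon bound to an aromatic nitrogen gives no change at the digits printed from compound 3 to compound 4 (within the scatter) and supplies the first direct comparison between two compounds that differ in one place. Among these compounds, it shows that this position accepts the (benzyloxycarbonyl)methyl group without a step beyond the scatter, something that the separate readings of the earlier compounds could not show. No available evidence bears on this result.

The compounds shown leave open whether a carboxylic acid in place of the benzyl ester, or an amine at this position, would move the reading. Among the compounds shown here, they also leave open whether a longer chain carrying the same ester would do so, since this single step covers only one change in chain length.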